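A few compounds are considered here, and "the series" means these few. Any claim that something is new, unique, unknown or untested is made for them only; others in the source may bear on it.

Measured so far:
- compound 1, `CCc1ccc2c(c1)c(=O)c(C(=O)Nc1ccc(Oc3ncnc4[nH]cc(-c5ccccc5)c34)c(F)c1)c(C)n2C`: 6 nM
- compound 2, `CCCc1ccc2c(c1)c(=O)c(C(=O)Nc1ccc(Oc3ncnc4[nH]cc(-c5ccccc5)c34)c(F)c1)c(C)n2C`: 61 nM

Both numbers come from an assay on isolated protein for inhibition of tyrosine-protein kinase receptor UFO (Homo sapiens), read by FRET and Z'-LYTE, with a stated time of 1.5 h; a higher number here means a weaker inhibitor, a lower number a stronger inhibitor. Among the measured compounds shown here, compound 2 stands at the higher of the two, the weaker inhibitor; its only neighbour is compound 1, and the step of a 10-fold higher number from compound 1 to compound 2 (1.01 log units; beyond the scatter) is large and clearly beyond the scatter. That step lengthened the side chain on the core by one carbon and cost a great deal of potency.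

Compound 3, `Cc1c(C(=O)Nc2ccc(Oc3ncnc4[nH]cc(-c5ccccc5)c34)c(F)c2)c(=O)c2cc(C3CCCC3)ccc2n1C`, is not yet measured. Its difference from compound 2 is cyclopentyl in place of propyl on an aromatic carbon. For the measured compounds named here, the one measured step bears only loosely on this change: it shows that a small growth of this chain already weakened inhibition, but it says nothing about closing the chain into a ring. With a single data point pointing towards weaker binding as the group grows, a modest further loss is expected rather than a gain, with wide uncertainty. The expected step is a 1.5-fold higher number from compound 2 to compound 3 (0.17 log units; within the scatter). For compound 3 the estimate in this assay is 90 nM, with a range from 20 nM to 400 nM.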

Compound 3, half-maximal inhibitory concentration: 200 nM
Compound 3: the middle estimate sits 2.2-fold (0.35 log units) below what was measured, within the range that was stated.
By their numbers in this assay, from the lowest: compound 1; then compound 2; then compound 3.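

In this assay, tying the side chain into a ring brought no recovery of potency: cyclopentyl in place of propyl gives a 3.3-fold higher number from compound 2 to compound 3 (0.52 log units; beyond the scatter), which continues in the direction of the earlier lengthening of the chain. Measured against the best group here, cyclopentyl in place of ethyl gives a 33-fold higher number from compound 1 to compound 3 (1.52 log units; beyond the scatter), so among these three compounds ethyl is the group this position favours, and the number rises from ethyl to propyl to cyclopentyl with no compound going against that order. No outside measurement is available to account for this loss of potency.

The change from propyl to cyclopentyl goes from 3 carbon atoms to 5 and brings in a ring at the same time, so these compounds cannot separate the contribution of the added carbons from that of the ring. Open questions are whether pentyl, an open chain with the same carbon count as cyclopentyl, would land near compound 3, and whether a small ring such as cyclopropyl or a shorter group such as methyl would match or improve on compound 1.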